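Notes on the step from compound 3 to compound 4

The source may hold more compounds than are shown below. What is called first, only, known or untested is meant among the compounds shown, and "the series" means these compounds.

Measured in a functional assay on HL-60 cells (Homo sapiens) for antiproliferative activity, read by MTT assay (on this read-out higher numbers stand for weaker inhibition and lower numbers for stronger inhibition), so far:
- compound 1 `O[C@@H]1[C@@H](OCc2ccccc2)[C@H](OCc2ccccc2)[C@@H](COCc2ccccc2)O[C@@H]1CC1CCCCC1` gives 17200 nM
- compound 2 `CC[C@H]1O[C@H](COCc2ccccc2)[C@@H](OCc2ccccc2)[C@H](OCc2ccccc2)[C@H]1O` is reported as "not active" (no number reported)
- compound 3 `O[C@@H]1[C@@H](OCc2ccccc2)[C@H](OCc2ccccc2)[C@@H](COCc2ccccc2)O[C@H]1CC1CCCCC1` gives 4100 nM

Within the data shown here, compound 3 at 4100 nM holds the lower of the two numbers, and compound 1 is the only other compound with a number. Compound 4 `C=CC[C@@H]1O[C@H](COCc2ccccc2)[C@@H](OCc2ccccc2)[C@H](OCc2ccccc2)[C@H]1O` differs from compound 3 by vinyl in place of cyclohexyl on a saturated chain carbon bound to a saturated ring carbon and carries vinyl in place of cyclohexyl on a saturated chain carbon bound to a saturated ring carbon. Cut one bond further out, the same difference reads cyclohexylmethyl to allyl.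

Among the measured compounds shown here, no measured step covers this exchange. For the measured compounds named here, the only measured step is a 4.2-fold lower number from compound 1 to compound 3 (0.62 log units; beyond the scatter) and it is modest. It reflects the fact that compounds 1 and 3 differ only in the configuration as drawn and so offers only a rough scale for the present change. Going by the values given here, compound 3 at 4100 nM has the lowest number so far, so a move to a higher number is the more likely outcome. Compound 2 shows that a result without a number also occurs in this set, and that outcome remains possible here. The expected change is a 3.7-fold higher number from compound 3 to compound 4 (0.56 log units; beyond the scatter) in this assay on this estimate. For compound 4 the estimated value is 15000 nM with an expected range of 5000 nM to 60000 nM in this reading.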

Compound 4, half-maximal inhibitory concentration: 15100 nM
Compound 4: middle estimate off by 1.0-fold (0.00 log units), on the low side; measured number inside the range.
By their numbers in this assay, from the lowest: compound 3; then compounds 4 and 1 (each within the scatter of the next).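

Until now this place had been read only through a change of configuration, and this assay now gives a step for a change of the group itself, cyclohexylmethyl to allyl: a 3.7-fold higher number from compound 3 to compound 4 (0.57 log units; beyond the scatter). Compound 4 has no ring in this group and still gives a number, so the cyclohexyl ring is not required for a measurable result in this assay, although keeping it goes with the lower number in this pair. Nothing available accounts for the size of this step.

This single exchange removes the ring and introduces the double bond together, so the contribution of each cannot be separated without a saturated open chain such as n-propyl at the same place. As far as these compounds go, it also remains open whether a phenyl ring, a longer chain, an amine or a carboxylic acid on this saturated chain carbon would give a lower number than compound 3 at 4100 nM, or whether such a group would leave the compound without a number.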